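The source may report more compounds than this note shows. Statements on the series, on what has been measured and on what is new or still open speak of the compounds shown alone.

Working notes on the series. Compound 1 `C[C@@H]1O[C@@H](N2C(=O)/C(=C3\Nc4ccccc4C3=O)c3ccccc32)[C@H](O)[C@H](O)[C@H]1O` is the reference point: in a functional assay on MCF7 cells (Homo sapiens) for antiproliferative activity, read by crystal violet staining, with a stated time of 96 h (a higher number here means a weaker inhibitor, a lower number a stronger inhibitor), compound 1 gives 670 nM. For the measured compounds named here, compound 2 `C[C@@H]1O[C@H](N2C(=O)/C(=C3\Nc4ccc(Cl)cc4C3=O)c3ccccc32)[C@H](O)[C@H](O)[C@H]1O` carries a chloro group on the shared core and, in this assay, compound 2 gives 7980 nM, the highest of the two numbers so far; compound 1 stands a step below it that lies beyond the scatter, so compound 2 is the weaker inhibitor of the pair.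

The next compound, compound 3 `C[C@@H]1O[C@@H](N2C(=O)/C(=C3\Nc4ccc(Cl)cc4C3=O)c3ccccc32)[C@H](O)[C@H](O)[C@H]1O`, keeps the chloro group. Its relation to compound 2: the two compounds have the same atoms and bonds and differ only in configuration as drawn: 1 of 6 stereo elements differ; a stereocentre at a saturated ring carbon is drawn S in compound 2 and R in compound 3. Going by the values given here, no measured pair in the set differs by configuration alone, so the size of this step cannot be read off earlier data. Given that compound 2 sits at the top of the range with 7980 nM, a move toward lower numbers is expected, though of uncertain size, and a step of about a 6.7-fold lower number from compound 2 to compound 3 (0.82 log units; beyond the scatter) is estimated in this assay. For compound 3 an expected value of 1200 nM is put down, with a range from 400 nM to 4000 nM.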

Compound 3, half-maximal inhibitory concentration: 6960 nM
For compound 3 the middle estimate is 5.8-fold (0.76 log units) below the measured one, and the stated range ends below it.
By their numbers in this assay, from the lowest: compound 1; then compounds 3 and 2 (each within the scatter of the next).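

The stereocentre at the saturated ring carbon, drawn S or R, carries almost no weight here: in this assay the change gives a 1.1-fold lower number from compound 2 to compound 3 (0.06 log units; within the scatter), so with the chloro group present this configuration does not separate the two compounds. With the configuration matched, the set now holds its first comparison that differs only in the aromatic substituent: chloro in place of hydrogen on an aromatic carbon gives a 10-fold higher number from compound 1 to compound 3 (1.02 log units; beyond the scatter), a large step against the chloro compound in this assay. The reading of the stereocentre rests on one pair only, and that pair isolates configuration from every other structural feature: the fact that compounds 2 and 3 differ only in the configuration as drawn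

Still open is whether the same stereocentre is equally silent when hydrogen rather than chloro sits on that aromatic carbon, as the only comparison of configuration shown here carries the chloro group. Also open, on these data alone, is whether the large step is particular to chloro or would also follow other groups on that carbon, such as fluoro, methoxy or an amine.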